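Hydrogen in Place of tert-Butoxycarbonyl on an Amide Nitrogen

The source may report more compounds than this note shows. Statements on the series, on what has been measured and on what is new or still open speak of the compounds shown alone.

The account begins with compound 1, `O=C(c1ccc(Cn2oc3ccccc3c2=O)cc1)N1CCCCC1`, which in an ADME assay on RAW264.7 cells (Mus musculus) for cytotoxicity, read by WST assay (a higher number here means that more compound is tolerated, a lower number that less compound is tolerated), gives 66200 nM. Compound 2, `CC(C)(C)OC(=O)N(Cc1ccco1)C(=O)c1ccc(Cn2oc3ccccc3c2=O)cc1`, returns no number in this assay but only a limit, > 100000 nM. Where compound 2 stands is therefore described by the limit of > 100000 nM in this assay, at which 1 of the 2 values shown sits, and nothing more exact is known about it. Compound 3, `O=C(NCc1ccco1)c1ccc(Cn2oc3ccccc3c2=O)cc1`, differs from compound 2 in one place: hydrogen in place of tert-butoxycarbonyl on an amide-type nitrogen. Going by the values given here, no measured step connects two compounds that differ in just this way, so the size of the change has to be estimated. The step from compound 2 to compound 3 in this assay is expected to be small, an at least 1.1-fold lower number from compound 2 to compound 3 (0.04 log units; that floor lies within the scatter), and not clearly beyond the scatter in either direction. Compound 3 is estimated to give 90000 nM, in a range from 40000 nM to 200000 nM.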

Compound 3, concentration lethal to 50% of the cells: > 100000 nM
Compound 3 was reported as a limit (the forecaster's own chance of this, stated with the estimate: 50%); middle value at least 1.1-fold (0.04 log units) from the limit.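

Compound 3 is reported only as a limit of the assay, just as compound 2 is, so hydrogen in place of tert-butoxycarbonyl on the amide-type nitrogen brings no number into view, and the step between them cannot be read. Both compounds stay at the same limit: the limit of > 100000 nM in this assay, at which 2 of the 3 values shown sit. The new compound also links to compound 1, where ((furan-2-yl)methyl)amino in place of piperidin-1-yl on the carbonyl carbon gives, in this assay, an at least 1.5-fold higher number from compound 1 to compound 3 (0.17 log units; that floor lies within the scatter), a floor that does not by itself clear the scatter.

From the compounds shown here alone, how far the true values of compound 2 and compound 3 lie past the limit remains open. Going by these compounds, it is also open whether a methyl group in place of the amide hydrogen, or a carboxylic acid or an amine on the furan ring, would give a measurable number.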